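Cytotoxicity notes: aryl amides on a shared bis(trifluoromethyl)benzoyl core

This account rests on a few compounds, and the source may have more. Where it says the series, first, only, none or still open, it means among the compounds named here.

Measured so far in an ADME assay on PC-3 cells (Homo sapiens) for cytotoxicity, read by WST assay, tested at 100 uM; on this read-out higher numbers stand for more inhibition at the one concentration tested (going by the name of the read-out) and lower numbers for less inhibition:
compound 1 `CC(C)(C)OC(=O)c1cccc(NC(=O)C2CCCN(C(=O)c3cc(C(F)(F)F)cc(C(F)(F)F)c3)C2)c1`: 0%
compound 2 `O=C(Nc1ccc(Cl)cc1)C1CCCN(C(=O)c2cc(C(F)(F)F)cc(C(F)(F)F)c2)C1`: 14%
compound 3 `COc1cccc(NC(=O)C2CCCN(C(=O)c3cc(C(F)(F)F)cc(C(F)(F)F)c3)C2)c1`: 0%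

Compound 3 sits at the bottom of this small set: in this assay compound 3 is level with compound 1 at the digits shown, and the only step beyond the scatter is a number 14 percentage points lower from compound 2 to compound 3 (beyond the scatter). The other step on record, no change at the digits printed from compound 1 to compound 3 (within the scatter), moves nothing.

Compound 4 `Cc1nc(-c2cccc(NC(=O)C3CCCN(C(=O)c4cc(C(F)(F)F)cc(C(F)(F)F)c4)C3)c2)cs1` differs from compound 3 as follows: 2-methyl-1,3-thiazol-4-yl in place of methoxy on an aromatic carbon.

Both measured steps alter the aryl group on the amide nitrogen, as this one does, and the largest of them was only modest. A small rise or no change beyond the scatter is therefore expected, so a number 8 percentage points higher from compound 3 to compound 4 (within the scatter) is the estimated step. For compound 4 the expected value in this assay is 8%, within 0% to 25%.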

Compound 4, a percentage reported as inhibition, at one concentration (the size of the read-out at that concentration, not a potency): 1%
Compound 4: middle estimate off by 7 percentage points, on the high side, and the stated range covers the measured number.
By their numbers in this assay, from the lowest: compounds 1, 3 and 4 (each within the scatter of the next); then compound 2.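

In this assay this aromatic carbon, meta to a large group, accepts a ring as well as open groups: a number 1 percentage points higher from compound 3 to compound 4 (within the scatter) and a number 1 percentage points higher from compound 1 to compound 4 (within the scatter) leave methoxy, tert-butoxycarbonyl and 2-methyl-1,3-thiazol-4-yl reading alike. The 4-chlorophenyl amide keeps its separation, with a number 13 percentage points lower from compound 2 to compound 4 (beyond the scatter) giving a step of the same kind as that to compound 3. No supporting evidence bears on these readings.

Open, from the compounds shown here alone, is whether an amine or a carboxylic acid on this carbon would read the same. Also open, going by these compounds, is whether the chlorine itself or its place on the ring sets compound 2 apart.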